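Notes on a pyrrolidinyl-amide series: microsomal stability

The source may hold more compounds than are shown below. What is called first, only, known or untested is meant among the compounds shown, and "the series" means these compounds.

Measured so far:
- compound 1, `CSc1ccc(-c2c(C)nc3c(N4CC[C@@H](NC(C)=O)C4)cc(C)nn23)cc1`: > 95% in an ADME assay on microsomes from liver (Mus musculus) for metabolic stability, read by LC-MS, with NADPH named in the record, with a stated time of 60 min, tested at 1 uM, in the absence of a further agent; a higher number here means that more of the compound is left, a lower number that less of the compound is left
- compound 2, `COc1ccc(-c2c(C)nc3c(N4CC[C@@H](NC(=O)Nc5ccccc5)C4)cc(C)nn23)cc1OC`: > 95% in this assay

Compound 1 sits at a limit of this assay, not at a number. Compound 2 likewise gives only a limit in this assay, and its value of > 95% is the upper bound of the reading. For the measured compounds named here, both values coincide at the limit of > 95% in this assay, at which 2 of the 2 values shown sit, so no step between them can be read, and nothing is known about how far either compound stands above that bound.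

Compound 3, `COc1ccc(-c2c(C)nc3c(N4CC[C@@H](NS(=O)(=O)c5ccc(C(C)=O)cc5)C4)cc(C)nn23)cc1OC`, is not yet measured. It differs from compound 2 only in one place: (4-acetylphenyl)sulfonyl in place of phenylcarbamoyl on an amine nitrogen. Going by the values given here, with no measured step to lean on, the expectation for compound 3 in this assay is a modest loss at most, a step of a number at least 10 percentage points lower from compound 2 to compound 3 (that floor lies within the scatter), which may well stay within the scatter. Compound 3 is therefore estimated at 85%, with a range from 60% to 98%, and a fair chance that the assay again reports only the limit.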

Compound 3, percent of the compound remaining: > 95%
Compound 3 ended at the assay's limit; the forecaster's own chance of this, stated with the estimate: 45%; middle value at least 10 percentage points away from the limit.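

Compound 3 gives > 95% in this assay, which is a limit and not a number. For the compounds shown here, no step from compound 2 to compound 3 can be read, because both sit at the same limit: the limit of > 95% in this assay, at which 3 of the 3 values shown sit.

The compounds shown leave open how far each stands from that limit, and whether any change on the amine nitrogen lowers the amount of compound remaining.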